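The source may hold more compounds than are shown below. What is called first, only, known or untested is meant among the compounds shown, and "the series" means these compounds.

Values in a functional assay on SK-OV-3 cells (Homo sapiens) for antiproliferative activity, read by MTT assay, with a stated time of 72 h; a higher number here means a weaker inhibitor, a lower number a stronger inhibitor:
- compound 1 `O=C(CCc1cccc2c1B(O)OC2)Nc1cccc(Br)c1`: 540 nM
- compound 2 `O=C(CCc1cccc2c1B(O)OC2)Nc1cccc(-c2ccc(C(F)(F)F)cc2)c1`: 500 nM
- compound 3 `N#Cc1ccc(-c2cccc(NC(=O)CCc3cccc4c3B(O)OC4)c2)cc1`: 340 nM

Compound 3, at 340 nM, is not separated from the other two compounds. The measured steps of a 1.6-fold lower number from compound 1 to compound 3 (0.20 log units; within the scatter), a 1.5-fold lower number from compound 2 to compound 3 (0.17 log units; within the scatter) and a 1.1-fold lower number from compound 1 to compound 2 (0.03 log units; within the scatter) all lie within the scatter.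

Compound 4 `CC(=O)c1cccc(-c2cccc(NC(=O)CCc3cccc4c3B(O)OC4)c2)c1` carries 3-acetylphenyl in place of 4-cyanophenyl on an aromatic carbon. Among the measured compounds shown here, no measured compound carries this group, and none of the three steps tests it directly. For the measured compounds named here, they show only that the changes made so far on this aromatic carbon stayed small. No step beyond the scatter is therefore expected in this assay, and no direction can be assigned. The estimated change is a 1.2-fold higher number from compound 3 to compound 4 (0.07 log units; within the scatter). For compound 4 the expected value is 400 nM, with an estimated range of 180 nM to 900 nM.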

Compound 4, half-maximal inhibitory concentration: 68 nM
Estimate against measurement, compound 4: 5.9-fold (0.77 log units) above; measured number outside the range, below it.
By their numbers in this assay, from the lowest: compound 4; then compounds 3, 2 and 1 (each within the scatter of the next).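

In this assay this aromatic carbon can move the number beyond the scatter: the change gives a 5.0-fold lower number from compound 3 to compound 4 (0.70 log units; beyond the scatter) and a 7.4-fold lower number from compound 2 to compound 4 (0.87 log units; beyond the scatter) and a 7.9-fold lower number from compound 1 to compound 4 (0.90 log units; beyond the scatter). The step from 4-cyanophenyl to 3-acetylphenyl changes both the group and its numbering on the added ring, and these two changes are not separated here. Nothing at hand bears on the reason for this step.

The compounds shown leave open whether the acetyl group or its placement carries the step, which 4-acetylphenyl and 3-cyanophenyl would tell. As far as these compounds go, how an amine or a carboxylic acid on that ring would read also stays open.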